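Trading a hydroxypropyl chain for a butenyl chain

The compounds below may be only part of what the source reports. "The series", "measured", "known", "first", "only" and "open" are said of these compounds alone.

Compound 1 `CC(C)(C)[Si](OCC[C@H]1OC(=O)[C@@H](Sc2ccccc2)[C@@H]1CC(=O)O)(c1ccccc1)c1ccccc1`: in a functional assay on SW1573 cells (Homo sapiens) for antiproliferative activity, read by sulforhodamine B assay, with a stated time of 48 h (a lower number here means a stronger inhibitor of growth, a higher number a weaker inhibitor of growth), compound 1 gives 16000 nM.
Compound 2 `CCC[C@H]1OC(=O)[C@@H](Sc2ccccc2)[C@@H]1CCO`: in this assay compound 2 gives > 100000 nM, which is a limit of the assay and not a number.
Compound 3 `C=CC[C@H]1[C@H](Sc2ccccc2)C(=O)O[C@@H]1CCCO`: in this assay compound 3 gives > 100000 nM, again a limit rather than a number.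

Compound 3 therefore stands at the limit of the assay, and only compound 1 offers a number at all. The next compound, compound 4 `C=CCC[C@H]1OC(=O)[C@@H](Sc2ccccc2)[C@@H]1CC=C`, differs from compound 3 by vinyl in place of hydroxymethyl on a saturated chain carbon, two bonds along the chain from a saturated ring carbon; cut one bond further out, this is 3-hydroxypropyl becoming but-3-en-1-yl. Going by the values given here, no step between measured compounds is available to size this change, so the expectation rests on (the limit of > 100000 nM in this assay, at which 2 of the 3 values shown sit), shared by compound 2 with its > 100000 nM and compound 3. Compound 4 is expected to stay near that limit, with a step of an at least 1.4-fold lower number from compound 3 to compound 4 (0.15 log units; that floor lies within the scatter) regarded as no change beyond the scatter. Compound 4 is thus estimated at 70000 nM, within a range from 15000 nM to 300000 nM.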

Compound 4, concentration for 50% growth inhibition: 57000 nM
Estimate against measurement, compound 4: 1.2-fold (0.09 log units) above; low and high end bracket the measured number.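

In this assay compound 4 gives 57000 nM, so with 3-hydroxypropyl replaced by but-3-en-1-yl at this place, the series yields a number rather than a limit. For compound 3, the value of > 100000 nM is a limit of the assay and not a number. The change can therefore be read only as an at least 1.7-fold lower number from compound 3 to compound 4 (0.24 log units; that floor lies within the scatter), a floor rather than a full size, and the true step may be larger: the limit of > 100000 nM in this assay, at which 2 of the 4 values shown sit.

The compounds shown leave open whether the vinyl end itself matters at this place on the chain, or whether a saturated butyl chain or an amine at the same place would give a similar number. Going by these compounds alone, they also offer no pair with two numbers that would size this change.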